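The source may hold more compounds than are shown below. What is called first, only, known or untested is meant among the compounds shown, and "the series" means these compounds.

Measured compounds:
compound 1 `CCC1(OC(=O)N2CCC(Oc3ncnc(Oc4ccc(S(C)(=O)=O)nc4C)c3F)CC2)CC1` — 22 nM
compound 2 `Cc1nc(S(C)(=O)=O)ccc1Oc1ncnc(OC2CCN(C(=O)OC3(C(F)(F)F)CCC3)CC2)c1F` — 14.3 nM
compound 3 `Cc1nc(S(C)(=O)=O)ccc1Oc1ncnc(OC2CCN(C(=O)OC3(C(F)(F)F)COC3)CC2)c1F` — 29.3 nM

All three compounds share one core and differ only in the group on an oxygen next to a carbonyl group. Their values come from a functional assay on isolated protein for inhibition of Glucose-dependent insulinotropic receptor (Homo sapiens), read by HTRF and cAMP accumulation; on this read-out higher numbers stand for an effect only at larger amounts of compound and lower numbers for an effect already at smaller amounts. Compound 3 has the highest number of the three, but its distance to compound 1 is small: a 1.3-fold higher number from compound 1 to compound 3 (0.12 log units; within the scatter). Its distance to compound 2 is larger: a 2.0-fold higher number from compound 2 to compound 3 (0.31 log units; beyond the scatter).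

Compound 4 `CCC(F)(F)C(=O)N1CCC(Oc2ncnc(Oc3ccc(S(C)(=O)=O)nc3C)c2F)CC1` departs further from this set. The change is 1,1-difluoropropyl in place of (3-(trifluoromethyl)oxetan-3-yl)oxy on a carbonyl carbon. The oxygen that carried the ring group is gone, and a short fluorinated chain sits directly on the carbonyl carbon.

The measured steps all exchange one group for another on that oxygen: a 1.5-fold lower number from compound 1 to compound 2 (0.19 log units; within the scatter), a 1.3-fold higher number from compound 1 to compound 3 (0.12 log units; within the scatter) and a 2.0-fold higher number from compound 2 to compound 3 (0.31 log units; beyond the scatter). None removes the oxygen itself, so they bear only loosely on this step; they show that changes at this end moved the number little. The step from compound 3 to compound 4 in this assay is therefore expected to be small, with uncertain direction, estimated as a 1.4-fold higher number from compound 3 to compound 4 (0.14 log units; within the scatter). Compound 4 is estimated at 40 nM, with a range from 15 nM to 110 nM.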

Compound 4, half-maximal effective concentration: 17.4 nM
Beside the measured number, compound 4's estimate is 2.3-fold (0.36 log units) above it; the range from low to high includes it.
By their numbers in this assay, from the lowest: compounds 2, 4, 1 and 3 (each within the scatter of the next, the first and the last beyond it).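

In this assay, the oxygen on the carbonyl carbon and the ring group it carried can both be replaced without a step beyond the scatter: putting 1,1-difluoropropyl in place of (3-(trifluoromethyl)oxetan-3-yl)oxy gives a 1.7-fold lower number from compound 3 to compound 4 (0.23 log units; within the scatter). The open chain also stands within the scatter of the other two ring groups, with a 1.2-fold higher number from compound 2 to compound 4 (0.09 log units; within the scatter) and a 1.3-fold lower number from compound 1 to compound 4 (0.10 log units; within the scatter), so among these four compounds neither that oxygen nor a ring is required for a number in this range. Nothing shown here gives a reason for this result.

The compounds shown leave open what the two fluorine atoms contribute, a question that plain propyl on the same carbonyl carbon would address. Also open, from the compounds shown here alone, is how a longer chain or an amine at this place would read.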